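A few compounds are considered here, and "the series" means these few. Any claim that something is new, unique, unknown or untested is made for them only; others in the source may bear on it.

Of the compounds shown here, three sharing one core have been tested in an assay on isolated protein for inhibition of malate dehydrogenase, mitochondrial (Sus scrofa), with stated times of 45 min and 30 min (on this read-out higher numbers stand for weaker inhibition and lower numbers for stronger inhibition), and each of them sits at the same limit rather than at a number. Compound 1 `O=S(=O)(Nc1ccc(-c2nc3ccccc3o2)cc1)c1cccc(F)c1` reaches only a limit in this assay, > 63000 nM. Compound 2 `O=S(=O)(Nc1ccc(-c2nc3ccccc3o2)cc1)c1ccccc1F` likewise gives in this assay a limit, > 63000 nM. Compound 3 `O=S(=O)(Nc1ccc(-c2nc3ccccc3o2)cc1)c1ccc(O)cc1` in this assay also gives a limit, > 63000 nM. The steps between them therefore cannot be read: from compound 1 to compound 2 the change is a step that the two limits leave unreadable from compound 1 to compound 2, from compound 1 to compound 3 it is a step that the two limits leave unreadable from compound 1 to compound 3, and from compound 2 to compound 3 it is a step that the two limits leave unreadable from compound 2 to compound 3. All that the numbers show is the limit of > 63000 nM in this assay, at which 3 of the 3 values shown sit, so compound 3 stands where the other two stand, with no order among them.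

Compound 4 `O=S(=O)(Nc1ccc(-c2nc3ccccc3o2)cc1)c1ccc(C(F)(F)F)cc1` is the next compound, not yet measured. It differs from compound 3 by trifluoromethyl in place of hydroxy on an aromatic carbon, on an aromatic carbon of a six-membered aromatic ring of carbon only. No measured step bears on this change, since every step shown is unreadable. The expectation is therefore that compound 4 remains at or near the limit, with an estimated step that the limit leaves unreadable from compound 3 to compound 4. Compound 4 is estimated in this assay at 100000 nM, with a range from 30000 nM to 400000 nM.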

Compound 4, half-maximal inhibitory concentration: > 63000 nM
Compound 4 ended at the assay's limit; the forecaster's own chance of this, stated with the estimate: 75%; the middle value lies beyond the limit too.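

No new step can be read from compound 3 to compound 4, since both compounds give a limit of the assay rather than a number, as does the whole set: the limit of > 63000 nM in this assay, at which 4 of the 4 values shown sit. The compounds shown leave open how strongly any of the four inhibits the enzyme, and whether changing the aromatic group on the sulfonyl sulfur alters that inhibition at all.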